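The source may report more compounds than this note shows. Statements on the series, on what has been measured and on what is new or still open speak of the compounds shown alone.

Within the data shown here, compound 2 `O=CN1CCN(c2ccc(Cl)cc2)C1=S` is the only compound with a number here: in a functional assay on NCI/ADR-RES cells (Homo sapiens) for inhibition, read by sulforhodamine B assay, with a stated time of 48 h (on this read-out higher numbers stand for weaker inhibition of growth and lower numbers for stronger inhibition of growth), compound 2 gives 36500 nM. Compound 1 `N#C/C(=C\N1CCN(C(=O)c2ccco2)C1=S)C(=O)c1ccccc1` carries no result, its entry in this assay being "not determined" (no result reported). Compound 3 `O=CN1CCN(c2ccc(Cl)c(Cl)c2)C1=S` differs from compound 2 by chloro in place of hydrogen on an aromatic carbon. Among the measured compounds shown here, no step between measured compounds is available, so the account rests on the structural change alone; a modest shift toward stronger growth inhibition, barely beyond the scatter, is expected, as a 1.8-fold lower number from compound 2 to compound 3 (0.26 log units; within the scatter). In this assay compound 3 is therefore estimated at 20000 nM, within the range 8000 nM to 60000 nM.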

Compound 3, concentration for 50% growth inhibition: 32900 nM
Compound 3: the middle estimate sits 1.6-fold (0.22 log units) below what was measured, and the stated range covers the measured number.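

In this assay, chloro in place of hydrogen on the aromatic carbon ortho to a chloro group gives a 1.1-fold lower number from compound 2 to compound 3 (0.05 log units; within the scatter), so compound 2 and compound 3 cannot be told apart. At this position, then, the added chlorine does not separate the two compounds on this read-out. Nothing at hand bears on the reason for this result. The compounds shown leave open what an amine or a carboxylic acid would do at this same position, and what the chloro group already present on compound 2 contributes.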